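The source may report more compounds than this note shows. Statements on the series, on what has been measured and on what is new or still open speak of the compounds shown alone.

Measured so far:
- compound 1, `COc1ccc(C2=NN(C3=NC(=O)/C(=C4\C(=O)Nc5ccc(Br)cc54)S3)C(c3ccc(OC)cc3)C2)cc1`, in a functional assay on cells (Cancer cell lines, Homo sapiens) for cytotoxicity, read by sulforhodamine B assay, with a stated time of 48 h (a higher number here means a weaker inhibitor of growth, a lower number a stronger inhibitor of growth), compound 1 gives 200 nM
- compound 2, `O=C1N=C(N2N=C(c3ccccc3)CC2c2ccc(Cl)cc2)S/C1=C1/C(=O)Nc2ccccc21`, in this assay compound 2 gives 270 nM
- compound 3, `COc1ccc(C2=NN(C3=NC(=O)/C(=C4\C(=O)Nc5ccccc54)S3)C(c3ccc(Cl)cc3)C2)cc1`, in this assay compound 3 gives 100000 nM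

Compound 3 has the highest number of the three, so it is the weakest inhibitor of growth in this set; compound 2 is its nearest neighbour and compound 1 its furthest. Within the data shown here, the one single-site step known here runs a 370-fold higher number from compound 2 to compound 3 (2.57 log units; beyond the scatter), a large loss of potency from a methoxy group replacing hydrogen.

Compound 4, `COc1ccc(C2=NN(C3=NC(=O)/C(=C4\C(=O)Nc5ccc(Br)cc54)S3)C(c3ccc(Cl)cc3)C2)cc1`, arises from compound 3 by bromo in place of hydrogen on an aromatic carbon. Among the measured compounds shown here, no measured pair differs only in this bromo, so no step bears directly on it. Compound 1 carries the same bromo and a far lower number than compound 3, but it also differs at another aryl ring, so the two values alone cannot separate the contributions. The expectation for compound 4 is therefore a move toward stronger inhibition, but an uncertain one, with a step estimated as a 20-fold lower number from compound 3 to compound 4 (1.30 log units; beyond the scatter). For compound 4 the estimate in this assay is 5000 nM, within a range of 300 nM to 80000 nM.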

Compound 4, concentration for 50% growth inhibition: 140 nM
Compound 4: the middle estimate sits 36-fold (1.55 log units) above what was measured, and the stated range ends above it.
By their numbers in this assay, from the lowest: compounds 4, 1 and 2 (each within the scatter of the next); then compound 3.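

In this assay, among these compounds, bromo in place of hydrogen on this aromatic carbon of the fused two-ring system has a large effect, with a 710-fold lower number from compound 3 to compound 4 (2.85 log units; beyond the scatter), and this is the first direct reading of the change at this position. With bromo present, the step of a 1.4-fold lower number from compound 1 to compound 4 (0.15 log units; within the scatter) lies within the scatter, so chloro and methoxy at that other aromatic carbon cannot be told apart in this pair. Nothing available explains why bromo has so large an effect here.

As far as these compounds go, whether bromo is needed at this carbon, or whether fluoro, methyl or an amine would serve as well, stays open. Also open is whether bromo would have a similar effect on compound 2, which has no methoxy group, as this is the only bromo-for-hydrogen pair shown.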